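Swapping the Methyl Ester for a Free Acid

A few compounds are considered here, and "the series" means these few. Any claim that something is new, unique, unknown or untested is made for them only; others in the source may bear on it.

Compound 1 (`CC#CCn1c(N2CCC[C@@H](N)C2)cc(=O)n(Cc2ccc(Br)c(C(=O)OC)c2)c1=O`) gives 82.7%
Compound 2 (`CC#CCn1c(N2CCC[C@@H](N)C2)cc(=O)n(Cc2ccc(F)c(C(=O)OC)c2)c1=O`) gives 81.8%
Compound 3 (`CC#CCn1c(N2CCC[C@@H](N)C2)cc(=O)n(Cc2ccc(Cl)c(C(=O)OC)c2)c1=O`) gives 64.1%
Compound 4 (`CC#CCn1c(N2CCC[C@@H](N)C2)cc(=O)n(Cc2ccc(Br)c(C(=O)O)c2)c1=O`) has not been measured yet

The values above come from an ADME assay on a cell-free system (plasma, Rattus norvegicus, strain Sprague-Dawley) for metabolic stability, read by LC-MS, with a stated time of 120 min, tested at 1 uM; a lower number here means that less of the compound is left, a higher number that more of the compound is left. Compound 1 sits level with compound 2 within the scatter and clear of compound 3, as two steps show. Fluoro in place of bromo gives a number 0.9 percentage points lower from compound 1 to compound 2 (within the scatter) on the aromatic carbon, and chloro in place of bromo gives a number 18.6 percentage points lower from compound 1 to compound 3 (beyond the scatter) on that same carbon.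

The change to compound 4 lies elsewhere: hydrogen in place of methyl on an oxygen next to a carbonyl group with hydrogen in place of methyl on an oxygen next to a carbonyl group, so methoxycarbonyl becomes carboxy. Among the measured compounds shown here, no measured step touches this place, so the halogen swaps offer only a rough yardstick for size, and the direction is a judgement. With compound 1 at 82.7% little room remains, so only a small rise is expected. The expected change is a number 9.3 percentage points higher from compound 1 to compound 4 (within the scatter) by this estimate. Compound 4 is expected at 92% with an estimated range from 78% to 104% in this assay.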

Compound 4, percent of the compound remaining: 19.2%
Compound 4: the middle estimate sits 72.8 percentage points above what was measured, and the stated range ends above it.
By their numbers in this assay, from the lowest: compound 4; then compound 3; then compounds 2 and 1 (each within the scatter of the next).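

In this assay, the methoxycarbonyl group proves far more sensitive to change than the halogen on the aromatic carbon: hydrogen in place of methyl on the oxygen next to the carbonyl group gives a number 63.5 percentage points lower from compound 1 to compound 4 (beyond the scatter) on moving to the carboxy group. Among the earlier compounds, which all keep methoxycarbonyl and vary only the halogen, the largest shift is smaller, at a number 18.6 percentage points lower from compound 1 to compound 3 (beyond the scatter) for chloro in place of bromo. No measurement here explains why so much less of the free acid remains.

On these data alone, the carboxy group appears only with bromo, so whether fluoro or chloro would show the same loss remains open. Also open, as far as these compounds go, is how an ethyl ester or a primary amide at this place would fare in this assay against the methyl ester and the free acid.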